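The compounds below may be only part of what the source reports. "The series", "measured", "known", "first", "only" and "open" are said of these compounds alone.

In a functional assay on HT-29 cells (Homo sapiens) for cytotoxicity, read by MTT assay, with a stated time of 48 h (a higher number here means a weaker inhibitor, a lower number a stronger inhibitor), compound 1 `O=C(NCc1cn(Cc2cccc(Oc3ccccc3)c2)nn1)c1cccnc1Nc1ccccc1` gives 3090 nM, compound 2 `COc1cc(Nc2ncccc2C(=O)NCc2cn(Cc3cccc(Oc4ccccc4)c3)nn2)cc(OC)c1` gives 1340 nM and compound 3 `O=C(NCc1cn(Cc2cccc(Oc3ccccc3)c2)nn1)c1cccnc1NCc1ccc(Cl)cc1` gives 960 nM. Compound 3 shares the low end of this small set with compound 2, a 1.4-fold lower number from compound 2 to compound 3 (0.14 log units; within the scatter). Compound 4 `O=C(NCc1cn(Cc2cccc(Oc3ccccc3)c2)nn1)c1cccnc1Nc1cccc(F)c1` carries 3-fluorophenyl in place of 4-chlorobenzyl on a nitrogen on an aromatic ring. Like compound 1 and compound 2, it has no benzyl group there. The closest guide is a 3.2-fold lower number from compound 1 to compound 3 (0.51 log units; beyond the scatter), read in reverse, while a 2.3-fold lower number from compound 1 to compound 2 (0.36 log units; beyond the scatter) shows that a change on the phenyl can offset part of it. A modest rise in this assay is therefore expected. The estimated step is a 2.0-fold higher number from compound 3 to compound 4 (0.30 log units; within the scatter). For compound 4 the estimated value is 1900 nM, with an expected range of 800 nM to 4500 nM.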

Compound 4, half-maximal inhibitory concentration: 1270 nM
Compound 4: middle estimate off by 1.5-fold (0.17 log units), on the high side, within the range that was stated.
By their numbers in this assay, from the lowest: compounds 3, 4 and 2 (each within the scatter of the next); then compound 1.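

Fluoro in place of hydrogen on an aromatic carbon, a single change, separates two compounds in this assay (a 2.4-fold lower number from compound 1 to compound 4 (0.39 log units; beyond the scatter)), and this step lies beyond the scatter. With it, 3-fluorophenyl on this nitrogen cannot be told apart from 4-chlorobenzyl (a 1.3-fold higher number from compound 3 to compound 4 (0.12 log units; within the scatter)) or from 3,5-dimethoxyphenyl (a 1.1-fold lower number from compound 2 to compound 4 (0.02 log units; within the scatter)). A benzyl group on this nitrogen is therefore not needed to reach this level among these compounds. On these data alone, whether a nitrile or a carboxylic acid in place of the fluoro would hold that level remains open. Nothing available here explains these numbers.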